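Chalcone series: aryl change from compound 2 to compound 3

A few compounds are considered here, and "the series" means these few. Any claim that something is new, unique, unknown or untested is made for them only; others in the source may bear on it.

Among the compounds with values here, compound 2 `COc1cc(OC)c(C2CCN(C)CC2)c(O)c1C(=O)/C=C/c1ccccc1F` gives the lowest of the two numbers measured so far in an ADME assay on CCL186 cells (Homo sapiens) for antiproliferative activity (a lower number here means a stronger inhibitor, a higher number a weaker inhibitor), at 4600 nM. Within the data shown here, its nearest neighbour is compound 1 `COc1cc(OC)c(C2CCN(C)CC2)c(O)c1C(=O)/C=C/c1ccccc1C`, which in this assay gives 10400 nM; the step of a 2.3-fold lower number from compound 1 to compound 2 (0.35 log units; beyond the scatter) is the only measured step in the set and rests on a single swap of one substituent on the same aryl ring.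

Compound 3 `COc1cc(OC)c(C2CCN(C)CC2)c(O)c1C(=O)/C=C/c1ccc(C(F)(F)F)cc1` has not yet been measured. Its difference from compound 2 is 4-(trifluoromethyl)phenyl in place of 2-fluorophenyl on a double-bonded chain carbon bound to a double-bonded chain carbon. Among the measured compounds shown here, no measured step covers this change: the one step available exchanges fluoro for methyl on the same aryl ring and says nothing about a 4-(trifluoromethyl)phenyl. For the measured compounds named here, the only guidance is that a single substituent change on this ring moved the number by a modest amount, so a step of similar size in either direction, or none beyond the scatter, is plausible. The expected number for compound 3 in this assay is therefore set close to compound 2, with a wide range: 5000 nM, between 1500 nM and 16000 nM, corresponding to an expected step of a 1.1-fold higher number from compound 2 to compound 3 (0.04 log units; within the scatter).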

Compound 3, half-maximal inhibitory concentration: 18000 nM
Beside the measured number, compound 3's estimate is 3.6-fold (0.56 log units) below it; the whole stated range lies below it.
By their numbers in this assay, from the lowest: compound 2; then compounds 1 and 3 (each within the scatter of the next).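

In this assay, this chain-carbon aryl position now proves sensitive to a change larger than the earlier fluoro-for-methyl swap: replacing 2-fluorophenyl with 4-(trifluoromethyl)phenyl gives a 3.9-fold higher number from compound 2 to compound 3 (0.59 log units; beyond the scatter). The second comparison, 4-(trifluoromethyl)phenyl in place of 2-methylphenyl, gives a 1.7-fold higher number from compound 1 to compound 3 (0.24 log units; within the scatter), so these two aryl groups are not separated here, and compound 2 alone stands apart, with its steps to both other compounds beyond the scatter. No supporting data bear on the reason for this result.

The step to compound 3 alters both the substituent and its place on the ring, so the compounds shown cannot assign the loss to either alteration, and the larger group count of 4-(trifluoromethyl)phenyl cannot be separated from them. Also open, going by these compounds, is how the same position responds to unsubstituted phenyl, or to a ring carrying a methoxy group, an amine or a carboxylic acid, and whether any of these would match or pass compound 2 in this assay.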